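A few compounds are considered here, and "the series" means these few. Any claim that something is new, unique, unknown or untested is made for them only; others in the source may bear on it.

Measured so far in an ADME assay on cells (Peritoneal macrophage, Mus musculus, strain Balb/c) for cytotoxicity, read by resazurin assay, with a stated time of 72 h; on this read-out lower numbers stand for higher toxicity in this test and higher numbers for lower toxicity in this test:
compound 1 `CC1(Cc2ccc(/C(N)=N/O)cc2)CC(S(=O)(=O)c2ccc(F)cc2)=C(c2ccc(/C(N)=N/O)cc2)O1`: 42200 nM
compound 2 `CC1(Cc2cccc(/C(N)=N/O)c2)CC(S(=O)(=O)c2ccc(F)cc2)=C(c2ccc(/C(N)=N/O)cc2)O1`: 50200 nM
compound 3 `CC1(Cc2ccc(C(F)(F)F)cc2)CC(S(=O)(=O)c2ccc(F)cc2)=C(c2ccc(/C(N)=N/O)cc2)O1`: 103000 nM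

In this assay compound 3 gives 103000 nM, the highest of the three numbers and beyond the scatter of both others. The next structure to be tested is compound 4 `CC1(Cc2cccc(C(F)(F)F)c2)CC(S(=O)(=O)c2ccc(F)cc2)=C(c2ccc(/C(N)=N/O)cc2)O1`, and the change is 3-(trifluoromethyl)phenyl in place of 4-(trifluoromethyl)phenyl on a saturated chain carbon bound to a saturated ring carbon. Within the data shown here, no measured pair makes this exact exchange. Among the measured compounds shown here, the closest precedent is a 1.2-fold higher number from compound 1 to compound 2 (0.08 log units; within the scatter), which also swaps one group for another of equal heavy-atom count on a saturated chain carbon bound to a saturated ring carbon. That step lies within the scatter. The other two steps, a 2.4-fold higher number from compound 1 to compound 3 (0.39 log units; beyond the scatter) and a 2.1-fold higher number from compound 2 to compound 3 (0.31 log units; beyond the scatter), are modest, but they replace one kind of group with another, which does not happen here. They therefore bear on this change only indirectly. For the measured compounds named here, with a single precedent the basis is thin, and it contains no trifluoromethyl pair. Resting on the step to compound 2 a 1.2-fold higher number from compound 1 to compound 2 (0.08 log units; within the scatter), no change beyond the scatter is expected in this assay, and the estimated step is a 1.1-fold lower number from compound 3 to compound 4 (0.04 log units; within the scatter). Compound 4 is expected at 95000 nM, with an estimated range of 55000 nM to 165000 nM.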

Compound 4, half-maximal cytotoxic concentration: 49800 nM
Estimate against measurement, compound 4: 1.9-fold (0.28 log units) above; the whole stated range lies above it.
By their numbers in this assay, from the lowest: compounds 1, 4 and 2 (each within the scatter of the next); then compound 3.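

Placement on the aromatic ring now matters at this position, on a saturated chain carbon bound to a saturated ring carbon, in this assay: replacing 4-(trifluoromethyl)benzyl with 3-(trifluoromethyl)benzyl gives a 2.1-fold lower number from compound 3 to compound 4 (0.32 log units; beyond the scatter), whereas the only earlier exchange at this position between isomeric groups gave a 1.2-fold higher number from compound 1 to compound 2 (0.08 log units; within the scatter). With 3-(trifluoromethyl)phenyl in place, the trifluoromethyl group no longer separates the compound from those carrying the nitrogen-containing group, as a 1.0-fold lower number from compound 2 to compound 4 (0.00 log units; within the scatter) and a 1.2-fold higher number from compound 1 to compound 4 (0.07 log units; within the scatter) show, so among these four compounds only compound 3 stands apart from the rest. The exchange of that nitrogen-containing group for trifluoromethyl reads differently on paper in the two placements, but the two steps cannot be told apart: the same change on two cores in this assay, a 2.4-fold higher number (0.39 log units; beyond the scatter) from compound 1 to compound 3 and a 1.0-fold lower number (0.00 log units; within the scatter) from compound 2 to compound 4, 2.5-fold (0.39 log units) apart, within the scatter of two such steps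

The placement effect rests on one trifluoromethyl pair and one pair with the nitrogen-containing group, so its generality remains unsettled. Also open, on these data alone, is how a methoxy group, a carboxylic acid or an amine would read at the 3- and 4- positions named in these benzyl groups.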